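The source may hold more compounds than are shown below. What is called first, only, known or untested is meant among the compounds shown, and "the series" means these compounds.

Compound 3 has the structure `COc1ccc(-c2cccc(COc3ccc4c(c3)CN(C3CCCC3)C4=O)c2)cc1C(=O)O`. In an ADME assay on a cell-free system (plasma, Rattus norvegicus) for metabolic stability, read by LC-MS, with a stated time of 1 h, at 37 degrees C, tested at 100 uM (a lower number here means that less of the compound is left, a higher number that more of the compound is left), compound 3 gives 100%. Among the numbers that exist, compound 3 stands highest, though only by a small margin: its nearest neighbour, compound 1 with the structure `O=C(O)c1cc(-c2cccc(COc3ccc4c(c3)CN(C3CCCC3)C4=O)c2)ccc1O`, gives 98% in this assay, and the gap between the two lies within the scatter. A third compound, compound 2 with the structure `O=C1c2ccc(OCc3cccc(-c4ccc(C(F)(F)F)cc4F)c3)cc2CN1C1CCCC1`, gives "not determined" (no result reported) in this assay, so it cannot be placed.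

Compound 4, with the structure `COc1ccc(C(=O)O)cc1-c1cccc(COc2ccc3c(c2)CN(C2CCCC2)C3=O)c1`, is the one still to be measured. It keeps every atom of compound 3 and differs only in how one group is joined: 5-carboxy-2-methoxyphenyl in place of 3-carboxy-4-methoxyphenyl on an aromatic carbon.

Going by the values given here, the only measured step that speaks to this kind of change is a number 2 percentage points higher from compound 1 to compound 3 (within the scatter), a change on the same ring that left the read-out essentially unmoved and within the scatter. Both measured compounds sit near the top of the scale, so there is little room for a rise, and nothing seen so far suggests a drop. The expected step is therefore a number 2 percentage points lower from compound 3 to compound 4 (within the scatter), none beyond the scatter. Compound 4 is expected to give about 98% in this assay, within a range from 90% to 100%.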

Compound 4, percent of the compound remaining: 100%
The estimate for compound 4 lay 2 percentage points below the measured number; the measured number falls inside the stated range.
By their numbers in this assay, from the lowest: compounds 1, 3 and 4 (each within the scatter of the next).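

Moving the groups around this aromatic ring, with the same atoms joined differently, gives no change at the digits printed from compound 3 to compound 4 (within the scatter) in this assay. The earlier step showed only that a methyl on the ring oxygen leaves the read-out unmoved; this one shows the same for a rearrangement, in which 5-carboxy-2-methoxyphenyl takes the place of 3-carboxy-4-methoxyphenyl on an aromatic carbon of the shared core. The step that replaces 3-carboxy-4-hydroxyphenyl with 5-carboxy-2-methoxyphenyl, and so changes both the oxygen substituent and the arrangement, gives a number 2 percentage points higher from compound 1 to compound 4 (within the scatter), and no information here explains this steadiness.

All three compounds with a number carry a carboxylic acid on this ring and sit near the top of the scale, so a change of arrangement has been tested only on a ring with that acid and with a hydroxyl or methoxy group. As far as these compounds go, it remains open whether the read-out would hold if an amine or a nitrile stood in place of the carboxylic acid, or if a longer chain such as ethoxy stood in place of the methoxy group.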